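This account rests on a few compounds, and the source may have more. Where it says the series, first, only, none or still open, it means among the compounds named here.

Measured in a functional assay on the whole organism for agonist activity, with Mus musculus as the target; a higher number here means that more compound is needed for the effect, a lower number that less compound is needed:
- Compound 1 `CC1CCC(=O)N1CC#CCn1ccnc1`: > 100 mg/kg (a limit, not a number)
- Compound 2 `CC(=O)NCC#CCn1ccnc1`: > 100 mg/kg (a limit, not a number)
- Compound 3 `CC(=O)NCC#CCn1cncc1C`: 66 mg/kg

For the measured compounds named here, compound 3 carries the only actual number, 66 mg/kg. The rest of the picture is the limit of > 100 mg/kg in this assay, at which 2 of the 3 values shown sit.

The next compound, compound 4 `COC(=O)NCC#CCn1cncc1C`, differs from compound 3 by one change: methoxy in place of methyl on a carbonyl carbon. In words, this is methoxy in place of methyl on a carbonyl carbon, which turns acetamido into (methoxycarbonyl)amino.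

Going by the values given here, only one measured step can serve as a guide, an at least 1.5-fold lower number from compound 2 to compound 3 (0.18 log units; that floor lies within the scatter). That step is methyl in place of hydrogen on an aromatic carbon, so it concerns another part of the molecule and says little about the carbonyl. Among the compounds with values here, no measured step touches that group, so no direction can be argued, and no shift beyond the scatter is expected in this assay. The expected change is a 1.1-fold lower number from compound 3 to compound 4 (0.04 log units; within the scatter). The estimate for compound 4 is 60 mg/kg, with an expected range from 20 mg/kg to 180 mg/kg.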

Compound 4, dose for half-maximal effect: > 100 mg/kg
Compound 4: only a limit was reported (the forecaster's own chance of this, stated with the estimate: 35%); middle value at least 1.6-fold (0.22 log units) away from the limit.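

The acetamido end of the molecule now has a measured step of its own: in this assay, methoxy in place of methyl on the carbonyl carbon gives an at least 1.5-fold higher number from compound 3 to compound 4 (0.18 log units; that floor lies within the scatter). As far as these compounds go, compound 4 is reported only as a limit, so the true size of this step is unknown, and its printed floor does not separate it from the scatter. Turning acetamido into (methoxycarbonyl)amino thus gave no sign of a lower number, and compound 3 keeps the only actual value in the set: the limit of > 100 mg/kg in this assay, at which 3 of the 4 values shown sit.

Still open, from the compounds shown here alone, is how large this step really is. Also open, going by these compounds, is whether another group on this carbonyl carbon, such as an amine or a longer chain like ethyl, would give a number lower than that of compound 3.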